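Alkoxy versus alkylamino on the shared core: towards compound 4

A few compounds are considered here, and "the series" means these few. Any claim that something is new, unique, unknown or untested is made for them only; others in the source may bear on it.

Measured compounds in a functional assay (spleen, spleen) for activation, with Mus musculus as the target; a higher number here means that more compound is needed for the effect, a lower number that less compound is needed:
compound 1 `CCCCCOc1nc(N)c2nc(O)n(Cc3ccccc3)c2n1` — compound 1 gives 0.01 uM
compound 2 `Nc1nc(N)c2nc(O)n(Cc3ccccc3)c2n1` — compound 2 gives 10 uM
compound 3 `CCCCNc1nc(N)c2nc(O)n(Cc3ccccc3)c2n1` — compound 3 gives 1 uM

Compound 3 holds the second highest of the three numbers in this assay. Its nearest neighbour is compound 2, with a 10-fold lower number from compound 2 to compound 3 (1.00 log units; beyond the scatter); the furthest is compound 1, with a 100-fold higher number from compound 1 to compound 3 (2.00 log units; beyond the scatter). Compound 1 thus stands apart from both.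

Compound 4 `COc1nc(N)c2nc(O)n(Cc3ccccc3)c2n1` differs from compound 3 in one place: methoxy in place of butylamino on an aromatic carbon.

Among the measured compounds shown here, two measured steps bear on this. The step with a 100-fold higher number from compound 1 to compound 3 (2.00 log units; beyond the scatter) shows that an oxygen-linked chain gives a much lower number than a nitrogen-linked one, which speaks for the oxygen in compound 4. Against it, the step with a 10-fold lower number from compound 2 to compound 3 (1.00 log units; beyond the scatter) shows that the chain itself matters, and methoxy carries only a short one; the step with a 1000-fold higher number from compound 1 to compound 2 (3.00 log units; beyond the scatter) points the same way. The two effects pull in opposite directions, so the expected outcome for compound 4 in this assay is a number near that of compound 3: an no change at the digits printed from compound 3 to compound 4 (within the scatter) is expected, within the scatter.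

Compound 4 is estimated at 1 uM, with a range from 0.1 uM to 10 uM.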

Compound 4, minimum effective concentration: 0.1 uM
Beside the measured number, compound 4's estimate is 10-fold (1.00 log units) above it; the range from low to high includes it.
By their numbers in this assay, from the lowest: compound 1; then compound 4; then compound 3; then compound 2.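

The oxygen link at this position outweighs chain length in the pair compared here: in this assay, methoxy in place of butylamino gives a 10-fold lower number from compound 3 to compound 4 (1.00 log units; beyond the scatter), so the group with 2 heavy atoms gives a lower number than the one with 5 heavy atoms. Methoxy in place of amino gives a 100-fold lower number from compound 2 to compound 4 (2.00 log units; beyond the scatter), which shows that a short oxygen-linked group already accounts for much of what separates amino from pentyloxy on this aromatic carbon. Chain length within the oxygen-linked pair still counts, with a 10-fold higher number from compound 1 to compound 4 (1.00 log units; beyond the scatter), and no measurement shown here accounts for either the link or the chain effect.

With only methoxy and pentyloxy on oxygen, the compounds shown leave open how the number moves through ethoxy, propoxy and butoxy, and whether a chain longer than pentyloxy lowers it further. Also open, going by these compounds, is how butoxy compares directly with butylamino, and whether a sulfur-linked chain such as butylthio behaves like the oxygen-linked or the nitrogen-linked groups.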